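The source may hold more compounds than are shown below. What is called first, only, known or untested is meant among the compounds shown, and "the series" means these compounds.

Measured so far in a functional assay on A549 cells (Homo sapiens) for inhibition, read by sulforhodamine B assay, tested at 10 uM; on this read-out higher numbers stand for more inhibition of growth at the one concentration tested and lower numbers for less inhibition of growth:
- compound 1, `COc1cc(C2CC(c3ccc([N+](=O)[O-])cc3)=NN2C(C)=O)ccc1OCc1cn(Cc2ccc([N+](=O)[O-])cc2)nn1`, gives 39%
- compound 2, `COc1cc(C2CC(c3cc(OC)c(OC)c(OC)c3)=NN2C(C)=O)ccc1OCc1cn(Cc2ccc([N+](=O)[O-])cc2)nn1`, gives 68%

Compound 2 stands highest of the two numbers. Going by the values given here, the other number lies well below it: the step of a number 29 percentage points higher from compound 1 to compound 2 (beyond the scatter) is beyond the scatter, and it is the only step so far.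

The next compound is compound 3, `COc1cc(C2CC(c3ccc(Cl)cc3)=NN2C(C)=O)ccc1OCc1cn(Cc2ccc([N+](=O)[O-])cc2)nn1`, still to be measured in this assay. It differs from compound 2 in one place: 4-chlorophenyl in place of 3,4,5-trimethoxyphenyl on a carbon with a double bond to nitrogen. Among the compounds with values here, only the step into compound 2 bears on this change. There, a 4-nitrophenyl gave way to the 3,4,5-trimethoxyphenyl at the same carbon, and the number rose by a modest, real amount. Compound 3 now puts a 4-chlorophenyl on that carbon, a group without hydrogen-bond acceptors, as the 4-nitrophenyl of compound 1 also sits as a single substituent on the ring. Within the data shown here, no measured step tells directly what the 4-chlorophenyl does, so the expectation is a step back down, of roughly the size seen before but with wide uncertainty.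

The step for compound 3 is therefore expected to be a number 23 percentage points lower from compound 2 to compound 3 (beyond the scatter), in this assay. Compound 3 is estimated at 45%, in the range 25% to 65%.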

Compound 3, percent growth inhibition at one concentration: 0%
The estimate for compound 3 lay 45 percentage points above the measured number; measured number below the stated range.
By their numbers in this assay, from the lowest: compound 3; then compound 1; then compound 2.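

In this assay the carbon with a double bond to nitrogen proves able to take the read-out across the whole span of the series: 4-chlorophenyl in place of 3,4,5-trimethoxyphenyl gives a number 68 percentage points lower from compound 2 to compound 3 (beyond the scatter) and leaves compound 3 lowest of the three, with all of its steps beyond the scatter. Going by these compounds alone, the swap of chloro for nitro on an aromatic carbon gives a number 39 percentage points lower from compound 1 to compound 3 (beyond the scatter) and shows that the two phenyl groups carrying one substituent are not interchangeable here, something the single earlier step could not show. Nothing measured on these compounds accounts for either step.

Still open, on these data alone, is whether the high number of compound 2 needs all three methoxy groups or would hold with a 4-methoxyphenyl or a 3,4-dimethoxyphenyl on the same carbon. A plain phenyl and a 4-aminophenyl there would show whether the chloro lowers the number against an unsubstituted ring and how a ring bearing an amine compares with the nitro and chloro rings.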